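The source may report more compounds than this note shows. Statements on the series, on what has been measured and on what is new or still open speak of the compounds shown alone.

Compound 1 `Cc1cccc(CCCN2CCc3nc(C)c([C@H](OC(C)(C)C)C(=O)O)c(-c4cc(F)c5c(c4C)CCCO5)c3C2)c1` and compound 2 `Cc1nc2c(c(-c3cc(F)c4c(c3C)CCCO4)c1[C@H](OC(C)(C)C)C(=O)O)CN(CCCc1ccccc1)CC2` share one core and differ only by hydrogen in place of methyl on an aromatic carbon. In an ADME assay on MT2 cells (Homo sapiens) for cytotoxicity, read by XTT assay, with a stated time of 4 days (on this read-out higher numbers stand for lower toxicity in this test and lower numbers for higher toxicity in this test), compound 1 gives > 40000 nM, which is a limit of the assay and not a number. In this assay compound 2 gives > 40000 nM, again a limit rather than a number. The step that the two limits leave unreadable from compound 1 to compound 2 is therefore of unreadable size, since both values sit at the limit of > 40000 nM in this assay, at which 2 of the 2 values shown sit. Among the measured compounds shown here, compound 2 thus stands at a limit, and the one further value shown is a limit too.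

Compound 3 `Cc1ccc(CCCN2CCc3nc(C)c([C@H](OC(C)(C)C)C(=O)O)c(-c4cc(F)c5c(c4C)CCCO5)c3C2)cc1` differs from compound 2 by methyl in place of hydrogen on an aromatic carbon. For the measured compounds named here, the only measured step that bears on this change is a step that the two limits leave unreadable from compound 1 to compound 2, which concerns the same kind of small group on an aromatic carbon, and its size is hidden by the two limits. No readable step in this assay therefore supports expecting any change beyond the scatter. The step of a number no higher from compound 2 to compound 3 (the limit leaves the size open) is expected to be one of no change. Compound 3 is expected to give 40000 nM in this assay, within a range from 20000 nM to 80000 nM.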

Compound 3, half-maximal cytotoxic concentration: > 40000 nM
Compound 3 was reported as a limit; the forecaster's own chance of this, stated with the estimate: 85%; the middle value lies on the limit itself.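

Compound 3 gives > 40000 nM in this assay and this is a limit, not a number. Among the compounds shown here, no step among compound 1, compound 2 and compound 3 can therefore be read, because all their values sit at one limit: the limit of > 40000 nM in this assay, at which 3 of the 3 values shown sit. The compounds shown leave open whether adding the methyl group, or moving it on the phenyl ring, changes cytotoxicity at all.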